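Removing one methoxy group: what to expect of compound 4

This account rests on a few compounds, and the source may have more. Where it says the series, first, only, none or still open, it means among the compounds named here.

In a functional assay on TK-10 cells (Homo sapiens) for cytotoxicity, read by sulforhodamine B assay, with a stated time of 48 h, tested at 100 uM (on this read-out higher numbers stand for a weaker effect at the one concentration tested and lower numbers for a stronger effect), three compounds have been measured:
compound 1 `COc1ccc(-c2cc(/C=C/C(=O)c3ccc(N)cc3)[nH]n2)cc1` gives -91%
compound 2 `COc1ccc(-c2cc(/C=C/C(=O)c3ccc(N)cc3)[nH]n2)cc1OC` gives -98%
compound 3 `COc1cc(C(=O)/C=C/c2cc(-c3cc(OC)c(OC)c(OC)c3)n[nH]2)cc(OC)c1OC` gives -99%

Compound 1 differs from compound 2 by hydrogen in place of methoxy on an aromatic carbon; this gave a number 7 percentage points higher from compound 2 to compound 1 (within the scatter). How the core of compound 3 differs from that of compound 2 is not broken down here. Compound 4 `COc1ccc(-c2cc(/C=C/C(=O)c3cc(OC)c(OC)c(OC)c3)[nH]n2)cc1OC` differs from compound 3 by hydrogen in place of methoxy on an aromatic carbon, the same kind of change as from compound 2 to compound 1, though here the place is also meta to a methoxy group. Resting on the step of a number 7 percentage points higher from compound 2 to compound 1 (within the scatter), a step of about a number 5 percentage points higher from compound 3 to compound 4 (within the scatter) is expected. Compound 4 is therefore estimated at -94%, expected between -100% and -84%.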

Compound 4, a percentage reported as activity, at one concentration (the size of the read-out at that concentration, not a potency): -94%
The estimate for compound 4 equals the measured number at the digits printed; the measured number falls inside the stated range.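

In this assay, hydrogen in place of methoxy on an aromatic carbon gave a number 5 percentage points higher from compound 3 to compound 4 (within the scatter). Set beside the earlier case, the change reads alike on the two cores: the same change on two cores in this assay, a number 7 percentage points higher (within the scatter) from compound 2 to compound 1 and a number 5 percentage points higher (within the scatter) from compound 3 to compound 4, 2 percentage points apart, within the scatter of two such steps. This shows that the change produced no step beyond the scatter on either core, but it does not show how the change would read on any other core, nor does a read-out at one concentration say anything about potency.

The compounds shown leave open what a hydroxyl group or a chlorine atom would give in place of that methoxy group. They also leave open what a longer chain such as ethoxy would give there.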